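Amide substituent variation in a weakly antiproliferative isoquinolinone-type series

The compounds below may be only part of what the source reports. "The series", "measured", "known", "first", "only" and "open" are said of these compounds alone.

Measured compounds:
compound 1 `CN1CCC(NC(=O)c2ccc(Cn3nc(-c4cnn(C)c4)c4ccccc4c3=O)cc2)CC1`: 83300 nM
compound 2 `Cc1noc(C)c1-c1nn(Cc2ccc(C(=O)N3CCCCC3)cc2)c(=O)c2ccccc12`: > 100000 nM

Among the compounds with values here, in a functional assay on LoVo cells (Homo sapiens) for antiproliferative activity, read by MTT assay, with a stated time of 72 h (a higher number here means a weaker inhibitor, a lower number a stronger inhibitor), compound 1 gives 83300 nM, the only numerical value so far. Compound 2 is reported only as a limit, > 100000 nM, and not as a number. This leaves compound 1 as the sole fixed point; the other entry sits at the limit of > 100000 nM in this assay, at which 1 of the 2 values shown sits.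

Compound 3 `Cn1cc(-c2nn(Cc3ccc(C(=O)NC4CC4)cc3)c(=O)c3ccccc23)cn1` has not yet been measured. It differs from compound 1 by cyclopropyl in place of 1-methylpiperidin-4-yl on an amide-type nitrogen. Within the data shown here, no step between measured compounds exists against which this change can be read, and both known entries point to weak activity across the series.

The expectation for compound 3 is therefore a value close to compound 1, with a step of a 1.1-fold higher number from compound 1 to compound 3 (0.03 log units; within the scatter) that is not expected to exceed the usual scatter in either direction. The estimate for compound 3 is 90000 nM, with a range from 30000 nM to 300000 nM, and a real possibility that this assay returns only a limit.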

Compound 3, half-maximal inhibitory concentration: 48200 nM
Compound 3: middle estimate off by 1.9-fold (0.27 log units), on the high side, and the stated range covers the measured number.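

In this assay, within the data shown here, cyclopropyl in place of 1-methylpiperidin-4-yl on an amide-type nitrogen gives a 1.7-fold lower number from compound 1 to compound 3 (0.24 log units; within the scatter), the first step that can be read. Replacing a six-membered ring with one hetero atom by a three-membered ring of carbon only thus leaves compound 3 within the scatter of compound 1, and compound 3 is reported as a number rather than a limit. No measurement shown bears on the cause of this step.

Compound 2 stands only as a limit and differs from compound 1 in more than one place, so no step can be read from it. As far as these compounds go, whether any group on this nitrogen, such as a morpholine-bearing chain or a carboxylic acid, moves the number beyond the scatter remains open.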